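The source may report more compounds than this note shows. Statements on the series, on what has been measured and on what is new or still open speak of the compounds shown alone.

For the measured compounds named here, in a functional assay on HCT-15 cells (Homo sapiens) for cytotoxicity, read by ELISA, with a stated time of 4 days (on this read-out lower numbers stand for stronger inhibition and higher numbers for weaker inhibition), the series so far sits in one narrow band: compound 1 `Cc1ccsc1-c1cc(-c2ccco2)cc(-c2ccc(Cl)cc2)n1` gives 710 nM, compound 2 `Cc1ccccc1-c1cc(-c2ccoc2)cc(-c2ccc(Cl)s2)n1` gives 990 nM and compound 3 `Cc1cccc(-c2cc(-c3ccoc3)cc(-c3ccc(Cl)s3)n2)c1` gives 880 nM, so compound 3 lies within the scatter of both others. Compound 4 `Clc1ccc(-c2cc(-c3ccoc3)cc(-c3ccc(Cl)s3)n2)cc1` has 4-chlorophenyl in place of 3-methylphenyl on an aromatic carbon, next to the ring nitrogen (4-chlorophenyl in place of 3-methylphenyl on an aromatic carbon). Going by the values given here, the one measured step at this place is a 1.1-fold lower number from compound 2 to compound 3 (0.05 log units; within the scatter), which stays within the scatter. The 4-chlorophenyl group also occurs in compound 1, at 710 nM, though with other groups elsewhere on the core. No shift beyond the scatter is therefore expected in this assay, and the expected step is a 1.2-fold lower number from compound 3 to compound 4 (0.07 log units; within the scatter). Compound 4 is estimated at 750 nM, with an expected range of 350 nM to 1500 nM.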

Compound 4, half-maximal inhibitory concentration: 640 nM
Beside the measured number, compound 4's estimate is 1.2-fold (0.07 log units) above it, and the stated range covers the measured number.
By their numbers in this assay, from the lowest: compounds 4, 1, 3 and 2 (each within the scatter of the next).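

Beyond the shift of a methyl group between 2-methylphenyl and 3-methylphenyl, this position, next to the ring nitrogen, now also carries a chlorine-bearing phenyl without leaving the scatter in this assay: a 1.4-fold lower number from compound 3 to compound 4 (0.14 log units; within the scatter) and a 1.5-fold lower number from compound 2 to compound 4 (0.19 log units; within the scatter). With the 5-chlorothiophen-2-yl and furan-3-yl groups unchanged, these three aryl groups cannot be told apart at this place. No supporting data explain this flat response.

Still open, as far as these compounds go, is whether the band holds only for substituted phenyl groups. An amine, a carboxylic acid or a longer chain at this place could show whether the position responds at all.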